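This account rests on a few compounds, and the source may have more. Where it says the series, first, only, none or still open, it means among the compounds named here.

Measured compounds:
- compound 1, `Cc1ccccc1-n1nc(C)c2c1NC(=O)[C@H](C)S[C@@H]2c1ccc(-c2ccccc2)cc1`: 24%
- compound 2, `CCCc1ccccc1-n1nc(C)c2c1NC(=O)[C@H](C)S[C@@H]2c1ccc(Oc2ccccc2)cc1`: 240%

Compound 1 carries a phenyl group on the aryl ring attached to the shared core, and in an assay on isolated protein for agonist activity at Bile acid receptor (Homo sapiens), read by AlphaScreen, with a stated time of 30 min (a lower number here means a smaller maximal response, a higher number a larger maximal response), compound 1 gives 24%, the lowest of the two numbers available. Compound 2 differs from compound 1 in more than one place, so its values can only be set beside those of compound 1: in this assay compound 2 gives 240%, a gap far beyond the usual scatter, and the higher number belongs to the compound with an aryl ether in the position where compound 1 carries phenyl.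

Compound 3, `COc1ccccc1Oc1ccc([C@H]2S[C@@H](C)C(=O)Nc3c2c(C)nn3-c2ccccc2C)cc1`, has not yet been measured. It differs from compound 1 in one place: 2-methoxyphenoxy in place of phenyl on an aromatic carbon. Among the compounds with values here, the only measured compound with an ether linkage there, compound 2, gives the large reading above, though its other substituent also differs, so the comparison is loose.

The author expects the step of a number 96 percentage points higher from compound 1 to compound 3 (beyond the scatter) to be a large rise, well beyond the scatter, because compound 2 reaches 240% with a related ether. The estimate for compound 3 in this assay is 120%, within a range from 40% to 230%.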

Compound 3, largest response reached (reported as efficacy), in percent of the reference or control that the assay uses: 240%
Compound 3: middle estimate off by 120 percentage points, on the low side; the whole stated range lies below it.
By their numbers in this assay, from the lowest: compound 1; then compounds 2 and 3 (each within the scatter of the next).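

In this assay, replacing phenyl with 2-methoxyphenoxy on an aromatic carbon, para to a large group, gives a number 216 percentage points higher from compound 1 to compound 3 (beyond the scatter), while the rest of the molecule stays unchanged. The earlier pair differed in more than one place, so it could not tie any difference in maximal response to this position alone; this single change shows that the position can by itself carry a large step. No supporting data bear on why the step arises.

The 2-methoxyphenoxy group brings its ether oxygen, its added aromatic ring position and its methoxy group in one change, so the compounds shown do not separate what each part contributes on the core of compound 1, and an unsubstituted phenoxy group on that same core would be the direct test of the methoxy group. From the compounds shown here alone, it also remains open how an amine, a carboxylic acid or a longer alkoxy chain would read in this place, and the read-out gives only the largest response reached, which says nothing about the concentration needed to reach it.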